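Replacing diethylamino with 2-(methoxycarbonyl)pyrrolidin-1-yl on a carbonyl carbon

This account rests on a few compounds, and the source may have more. Where it says the series, first, only, none or still open, it means among the compounds named here.

In an in vivo functional assay on the whole organism for inhibition, with Rattus norvegicus as the target (on this read-out higher numbers stand for an effect only at larger amounts of compound and lower numbers for an effect already at smaller amounts), compound 3 `CCCCc1nc(C)c(CC(=O)N(CC)CC)c(=O)n1Cc1ccc(-c2ccccc2-c2nnn[nH]2)cc1` gives 0.089 mg/kg, within the scatter of the two other measured compounds: compound 1 `CCCCc1nc(C)c(CCC(=O)OCC)c(=O)n1Cc1ccc(-c2ccccc2-c2nnn[nH]2)cc1` gives 0.066 mg/kg and compound 2 `CCCCc1nc(C)c(CC(=O)O)c(=O)n1Cc1ccc(-c2ccccc2-c2nnn[nH]2)cc1` gives 0.13 mg/kg. The change leading to compound 4 `CCCCc1nc(C)c(CC(=O)N2CCC[C@H]2C(=O)OC)c(=O)n1Cc1ccc(-c2ccccc2-c2nnn[nH]2)cc1` is 2-(methoxycarbonyl)pyrrolidin-1-yl in place of diethylamino on a carbonyl carbon, with 2-(methoxycarbonyl)pyrrolidin-1-yl in place of diethylamino on a carbonyl carbon. The closest evidence is the exchange on that same carbonyl carbon, a 1.5-fold lower number from compound 2 to compound 3 (0.16 log units; within the scatter). The neighbouring exchanges, a 1.3-fold higher number from compound 1 to compound 3 (0.13 log units; within the scatter) and a 2.0-fold higher number from compound 1 to compound 2 (0.29 log units; within the scatter), were also small. None of them tests this ring-bearing group directly, so the range stays wide. The expected step is therefore none beyond the scatter, and the estimate is a 1.1-fold higher number from compound 3 to compound 4 (0.05 log units; within the scatter). For compound 4 the estimated value is 0.1 mg/kg, with an expected range from 0.04 mg/kg to 0.3 mg/kg.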

Compound 4, dose for half-maximal effect: 0.043 mg/kg
Compound 4: the middle estimate sits 2.3-fold (0.37 log units) above what was measured; low and high end bracket the measured number.
By their numbers in this assay, from the lowest: compounds 4, 1, 3 and 2 (each within the scatter of the next, the first and the last beyond it).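

In this assay, among these compounds, 2-(methoxycarbonyl)pyrrolidin-1-yl on the carbonyl carbon gives the first step at this place that passes the scatter (a 2.1-fold lower number from compound 3 to compound 4 (0.32 log units; beyond the scatter)), and the exchange for hydroxy also passes it (a 3.0-fold lower number from compound 2 to compound 4 (0.48 log units; beyond the scatter)). The step from the ester chain stays within the scatter (a 1.5-fold lower number from compound 1 to compound 4 (0.19 log units; within the scatter)). No measurement here explains the change. From the compounds shown here alone, it remains open whether the ring alone carries this step, since an unsubstituted pyrrolidine on that carbonyl carbon would test it. Going by these compounds, a free carboxylic acid in place of the methyl ester, or the opposite stereocentre, also remains open.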